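Nitro in Place of Sulfamoyl on the Ethyl Analogue

A few compounds are considered here, and "the series" means these few. Any claim that something is new, unique, unknown or untested is made for them only; others in the source may bear on it.

Compound 1 `Cn1nc(-c2ccnc(Nc3cccc([N+](=O)[O-])c3)n2)c2ccccc21` gives 490 nM in a functional assay on HCT-116 cells (Homo sapiens) for antiproliferative activity, read by MTT assay, with a stated time of 72 h; a lower number here means a stronger inhibitor of growth, a higher number a weaker inhibitor of growth. Compound 2 `Cn1nc(-c2ccnc(Nc3cccc(S(N)(=O)=O)c3)n2)c2ccccc21`, which carries sulfamoyl in place of nitro on an aromatic carbon, gives 1980 nM in this assay, a change of a 4.0-fold higher number from compound 1 to compound 2 (0.61 log units; beyond the scatter). Compound 3 `CCn1nc(-c2ccnc(Nc3cccc(S(N)(=O)=O)c3)n2)c2ccccc21` has methyl in place of hydrogen on a saturated chain carbon bound to an aromatic nitrogen, and in this assay compound 3 gives 9010 nM, the highest of the three numbers; the change is a 4.6-fold higher number from compound 2 to compound 3 (0.66 log units; beyond the scatter).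

Compound 4 `CCn1nc(-c2ccnc(Nc3cccc([N+](=O)[O-])c3)n2)c2ccccc21` differs from compound 3 by nitro in place of sulfamoyl on an aromatic carbon. Of the measured steps, only a 4.0-fold higher number from compound 1 to compound 2 (0.61 log units; beyond the scatter) bears directly on this exchange, being the same swap run the other way on the analogue with hydrogen on the chain carbon. The step of a 4.6-fold higher number from compound 2 to compound 3 (0.66 log units; beyond the scatter) does not touch the exchanged group. Whether the swap behaves alike on the methylated chain cannot be read from two compounds, yet nothing in the numbers argues against it, so a lower number beyond the scatter is expected. For compound 4 the expected step is a 3.9-fold lower number from compound 3 to compound 4 (0.59 log units; beyond the scatter). The estimate for compound 4 in this assay is 2300 nM, with a range from 1000 nM to 5500 nM.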

Compound 4, concentration for 50% growth inhibition: 2820 nM
Compound 4: the middle estimate sits 1.2-fold (0.09 log units) below what was measured; the range from low to high includes it.
By their numbers in this assay, from the lowest: compound 1; then compounds 2 and 4 (each within the scatter of the next); then compound 3.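

In this assay, nitro in place of sulfamoyl on the aromatic carbon gives a 3.2-fold lower number from compound 3 to compound 4 (0.50 log units; beyond the scatter), so this exchange can now be read on the core carrying the ethyl chain as well, and its size holds from one core to the other: the same change on two cores in this assay, a 4.0-fold higher number (0.61 log units; beyond the scatter) from compound 1 to compound 2 and a 3.2-fold higher number (0.50 log units; beyond the scatter) from compound 4 to compound 3, 1.3-fold (0.10 log units) apart, within the scatter of two such steps The added methyl on the saturated chain carbon can now also be read with nitro on the aromatic carbon, where it gives a 5.8-fold higher number from compound 1 to compound 4 (0.76 log units; beyond the scatter), and it too keeps its size whichever of the two groups is present: the same change on two cores in this assay, a 4.6-fold higher number (0.66 log units; beyond the scatter) from compound 2 to compound 3 and a 5.8-fold higher number (0.76 log units; beyond the scatter) from compound 1 to compound 4, 1.3-fold (0.10 log units) apart, within the scatter of two such steps Compounds 1, 2, 3 and 4 thus form a closed set in which each change has much the same size whatever the other place carries, and none of the four goes against this.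

The four compounds do not show whether this independence extends to other groups on that aromatic carbon, such as an amine or a carboxylic acid, or to a longer chain such as propyl on the aromatic nitrogen. They also leave open why either change moves the number as it does, since growth inhibition in this assay is the only read-out here.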